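From isopropyl to 3-methylphenyl on an aromatic nitrogen

The source may hold more compounds than are shown below. What is called first, only, known or untested is meant among the compounds shown, and "the series" means these compounds.

Of the compounds shown here, three sharing one core have been tested in a functional assay on HT-29 cells (Homo sapiens) for antiproliferative activity, read by MTT assay, with a stated time of 72 h (a higher number here means a weaker inhibitor, a lower number a stronger inhibitor), so far. Compound 1 (`COc1cc(-c2nccn2C(C)C)cc(OC)c1OC`) gives > 100000 nM there, which is a limit of the assay and not a number. Compound 1 therefore stands at the weak end of this small set, without an exact position.

Compound 2 (`COc1cc(-c2nccn2-c2ccc3sccc3c2)cc(OC)c1OC`) gives 1500 nM as a measured number. Compound 3 (`COc1cc(-c2nccn2-c2ccc3cc[nH]c3c2)cc(OC)c1OC`) gives 3600 nM as a measured number. Both carry an aromatic group on the nitrogen where compound 1 has isopropyl.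

Compound 4 (`COc1cc(-c2nccn2-c2cccc(C)c2)cc(OC)c1OC`) has 3-methylphenyl in place of isopropyl on an aromatic nitrogen. Among the measured compounds shown here, no measured pair shows this exact change. Even so, a large step towards stronger inhibition is expected in this assay, given the value of compound 2 (1500 nM) and that of compound 3 (3600 nM). The estimated change is an at least 20-fold lower number from compound 1 to compound 4 (1.30 log units; beyond the scatter), though its true size stays uncertain. For compound 4 the expected value is 5000 nM, with an estimated range from 800 nM to 30000 nM.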

Compound 4, half-maximal inhibitory concentration: 14600 nM
For compound 4 the middle estimate is 2.9-fold (0.47 log units) below the measured one; the measured number falls inside the stated range.
By their numbers in this assay, from the lowest: compound 2; then compound 3; then compound 4. At a limit, above all of these: compound 1.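

In this assay, putting 3-methylphenyl in place of isopropyl on the aromatic nitrogen gives an at least 6.8-fold lower number from compound 1 to compound 4 (0.83 log units; beyond the scatter), so the group at this position clearly matters. A single six-membered aromatic ring of carbon only, carrying a methyl group, is enough for this step, and compound 4 gives 14600 nM as a measured number. The true size of this step stays unknown because compound 1 has a limit of the assay and not a number: the limit of > 100000 nM in this assay, at which 1 of the 4 values shown sits.

Still open, on these data alone, is how plain phenyl at this nitrogen would compare with 3-methylphenyl, which would show what the methyl group itself adds. Also open, as far as these compounds go, is whether an amine or a methoxy group on that ring would move the number in either direction.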